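The compounds below may be only part of what the source reports. "The series", "measured", "known", "first", "only" and "open" are said of these compounds alone.

Of the compounds shown here, three sharing one core have been tested in a functional assay on PC-3 cells (Homo sapiens) for inhibition, read by sulforhodamine B assay, with a stated time of 48 h; a lower number here means a stronger inhibitor of growth, a higher number a weaker inhibitor of growth. Compound 2 `CC1=CC[C@H](C(C)(C)NC(=S)N/N=C/c2ccccc2O)CC1` gives 900 nM, the lowest of the three numbers. Compound 1 `COc1ccc(/C=N/NC(=S)NC(C)(C)[C@H]2CC=C(C)CC2)cc1` gives 1200 nM, and a 1.3-fold lower number from compound 1 to compound 2 (0.12 log units; within the scatter). Compound 3 `CC1=CC[C@H](C(C)(C)NC(=S)N/N=C/c2ccccc2[N+](=O)[O-])CC1` gives 6400 nM, and a 7.1-fold higher number from compound 2 to compound 3 (0.85 log units; beyond the scatter). Compound 4 `CC1=CC[C@H](C(C)(C)NC(=S)N/N=C/c2ccco2)CC1` has not yet been measured; its change from compound 2 is furan-2-yl in place of 2-hydroxyphenyl on a carbon with a double bond to nitrogen. Both measured steps only altered groups on the ring attached to the carbon with a double bond to nitrogen; neither replaced that ring itself. The change to compound 4 also removes the hydroxy group, and since a 7.1-fold higher number from compound 2 to compound 3 (0.85 log units; beyond the scatter) went with that loss, a modest rise in number is expected in this assay, a 2.0-fold higher number from compound 2 to compound 4 (0.30 log units; within the scatter). Compound 4 is estimated at 1800 nM, within a range from 700 nM to 5000 nM.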

Compound 4, concentration for total growth inhibition: 27200 nM
Beside the measured number, compound 4's estimate is 15-fold (1.18 log units) below it, outside the stated range (above it).
By their numbers in this assay, from the lowest: compounds 2 and 1 (each within the scatter of the next); then compound 3; then compound 4.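

In this assay, changing the ring itself at this position gives a larger shift than either earlier step, which only changed groups on the ring: there is a 30-fold higher number from compound 2 to compound 4 (1.48 log units; beyond the scatter) and a 23-fold higher number from compound 1 to compound 4 (1.36 log units; beyond the scatter) as well. Compounds 1, 2 and 3, each with a six-membered aromatic ring of carbon only here, all give lower numbers than compound 4, so the ring matters and not only its groups. Nothing shown explains this shift. Still open, on these data alone, is whether an amine or a carboxylic acid on the phenyl ring would keep a number as low as that of compound 2, and whether a group added to the furan-2-yl ring of compound 4 would recover any growth inhibition.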